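The source may hold more compounds than are shown below. What is called first, only, known or untested is meant among the compounds shown, and "the series" means these compounds.

For the measured compounds named here, in a functional assay on HeLa cells (Homo sapiens) for inhibition, read by MTT assay, with a stated time of 72 h (a lower number here means a stronger inhibitor, a higher number a weaker inhibitor), compound 1 `COc1cc(OC)c(C(=O)/C=C/c2ccc(O)cc2)c(OC)c1` gives 40600 nM, the highest of the three numbers so far. Compound 2 `COc1cc(OC)c(C(=O)/C=C/c2ccccc2OC)c(OC)c1` gives 19600 nM, and compound 3 `COc1cc(OC)c(C(=O)/C=C/c2ccc(O)c(O)c2)c(OC)c1` gives 15800 nM. Between these two lower values there is only a 1.2-fold lower number from compound 2 to compound 3 (0.09 log units; within the scatter).

Compound 4 `COc1cc(OC)c(C(=O)/C=C/c2ccc([N+](=O)[O-])cc2)c(OC)c1` has nitro in place of hydroxy on an aromatic carbon, a change counted as nitro in place of hydroxy on an aromatic carbon. Going by the values given here, no measured compound carries a nitro, so no measured step makes this exact exchange. The nearest guides are a 2.1-fold lower number from compound 1 to compound 2 (0.32 log units; beyond the scatter) and a 2.6-fold lower number from compound 1 to compound 3 (0.41 log units; beyond the scatter), both modest, and both alter the same aromatic ring that changes in compound 4. On that limited evidence, a modest move towards a lower number is expected in this assay, of about the same size as those two steps. The expected step is a 2.1-fold lower number from compound 1 to compound 4 (0.33 log units; beyond the scatter). The estimated value for compound 4 is 19000 nM. The expected range for compound 4 runs from 8000 nM to 45000 nM.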

Compound 4, half-maximal inhibitory concentration: 8000 nM
For compound 4 the middle estimate is 2.4-fold (0.38 log units) above the measured one; the measured number falls inside the stated range.
By their numbers in this assay, from the lowest: compounds 4, 3 and 2 (each within the scatter of the next, the first and the last beyond it); then compound 1.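

Exchanging hydroxy for nitro on the aromatic carbon para to a large group gives a 5.1-fold lower number from compound 1 to compound 4 (0.71 log units; beyond the scatter) in this assay, so at this place the hydroxy, with its hydrogen-bond donor, is not needed for a lower number. Losing that hydroxy is not the only route to a lower number, however: with the hydroxy kept and a second one added, the change is a 2.6-fold lower number from compound 1 to compound 3 (0.41 log units; beyond the scatter). Nothing available explains why the nitro exchange lowers the number in this way.

From the compounds shown here alone, what the nitro contributes apart from the loss of the hydroxy stays open. Going by these compounds, it also remains open how an amine or a carboxylic acid on this same aromatic carbon would compare in this assay.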